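A few compounds are considered here, and "the series" means these few. Any claim that something is new, unique, unknown or untested is made for them only; others in the source may bear on it.

Measured compounds:
Compound 1, `CCc1nc(Cl)c(C2C(C(=O)OC)=C(C)NC(C)=C2C(=O)OC)[nH]1`, gives 0.596 nM in an assay on ileum for inhibition of Voltage-dependent L-type calcium channel subunit alpha-1C (Cavia porcellus); a higher number here means a weaker inhibitor, a lower number a stronger inhibitor.
Compound 2, `CCc1nc(Cl)c(C2C(C(=O)OC)=C(C)NC(C)=C2C(=O)OC(C)C)[nH]1`, gives 0.488 nM in this assay.

Within the data shown here, compound 2 has the lower of the two numbers seen so far in this assay, but its only neighbour is compound 1, and the step of a 1.2-fold lower number from compound 1 to compound 2 (0.09 log units; within the scatter) stays within the scatter, so the two compounds cannot be told apart on these numbers.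

Compound 3, `CCc1nc(Cl)c(C2C(C(=O)OC)=C(C)NC(C)=C2C(=O)OCc2ccccc2)[nH]1`, has not yet been measured in this assay. It differs from compound 2 in one place: benzyl in place of isopropyl on an oxygen next to a carbonyl group. Among the measured compounds shown here, the only measured step that touches this same oxygen is a 1.2-fold lower number from compound 1 to compound 2 (0.09 log units; within the scatter), where the ester group was also enlarged and the number barely moved. That single step is the whole basis for judging the change to benzyl, and it gives no sign that growth at this position shifts the number beyond the scatter. Compound 3 is therefore expected to stay close to compound 2, with the step of a 1.2-fold lower number from compound 2 to compound 3 (0.07 log units; within the scatter) expected to lie within the scatter. The estimate for compound 3 in this assay is 0.42 nM, with a range from 0.15 nM to 1.2 nM.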

Compound 3, half-maximal inhibitory concentration: 1.75 nM
Beside the measured number, compound 3's estimate is 4.2-fold (0.62 log units) below it; the measured number lies above the stated range.
By their numbers in this assay, from the lowest: compounds 2 and 1 (each within the scatter of the next); then compound 3.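

In this assay, the oxygen next to a carbonyl group turns out not to be indifferent to what it carries: methyl and isopropyl could not be told apart, with a 1.2-fold lower number from compound 1 to compound 2 (0.09 log units; within the scatter), but benzyl gives a 3.6-fold higher number from compound 2 to compound 3 (0.55 log units; beyond the scatter) and, set against methyl, a 2.9-fold higher number from compound 1 to compound 3 (0.47 log units; beyond the scatter). The position therefore accepts growth from methyl to isopropyl without a readable change, and the first shift beyond the scatter comes with the group that brings in a six-membered aromatic ring of carbon only, although both steps are modest and compound 3 still gives 1.75 nM. Nothing available here bears on why the number rises with benzyl.

Benzyl differs from isopropyl both in its size and in its ring, so these compounds cannot show which of the two goes with the higher number; cyclohexylmethyl, with a saturated ring, or n-butyl, a longer open chain, on the same oxygen would speak to that. Also open, going by these compounds, is how this position would respond to a chain ending in an amine or a carboxylic acid.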